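This account rests on a few compounds, and the source may have more. Where it says the series, first, only, none or still open, it means among the compounds named here.

Measured in a physicochemical assay for solubility, at pH 7.4; a lower number here means a less soluble compound, a higher number a more soluble compound:
- compound 1 `CN1CCN(c2ccc(C(=O)/C=C/c3cccc(/C=C/C(=O)NO)c3)cc2)CC1`: 15000 nM
- compound 2 `O=C(/C=C/c1cccc(/C=C/C(=O)c2ccccc2)c1)NO`: 12000 nM
- compound 3 `CN1CCN(c2cccc(C(=O)/C=C/c3ccc(/C=C/C(=O)NO)nc3)c2)CC1`: 104000 nM

Compound 3 holds the highest of these three numbers. Its 104000 nM stands well clear of compound 1 at 15000 nM and of compound 2 at 12000 nM.

The next compound to consider is compound 4 `O=C(/C=C/c1ccc(/C=C/C(=O)c2ccccc2)cn1)NO`, which has not yet been measured. It comes from compound 3 by a single change: hydrogen in place of 4-methylpiperazin-1-yl on an aromatic carbon. In words, hydrogen takes the place of 4-methylpiperazin-1-yl on an aromatic carbon.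

For the measured compounds named here, one measured step bears on this, the same swap made on the core of compound 1: a 1.3-fold lower number from compound 1 to compound 2 (0.10 log units; within the scatter). That step was small. However, the core of compound 3 is not the core of compound 1, so the step is only a guide, and only one such step has been measured. On that evidence, no change beyond the scatter is expected, though a larger fall remains possible and the range is kept wide.

The expected change is a 1.3-fold lower number from compound 3 to compound 4 (0.11 log units; within the scatter). For compound 4 the estimated value in this assay is 80000 nM, with an expected range from 25000 nM to 130000 nM.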

Compound 4, solubility: 27000 nM
Compound 4: middle estimate off by 3.0-fold (0.47 log units), on the high side, within the range that was stated.
By their numbers in this assay, from the lowest: compounds 2, 1 and 4 (each within the scatter of the next, the first and the last beyond it); then compound 3.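

In this assay, taking away 4-methylpiperazin-1-yl from its place on an aromatic carbon, meta to a large group, gives a 3.9-fold lower number from compound 3 to compound 4 (0.59 log units; beyond the scatter) on the core of compound 3, while the same swap on the core of compound 1 gave a 1.3-fold lower number from compound 1 to compound 2 (0.10 log units; within the scatter) and so could not be told apart from the noise of repeat measurements. This swap therefore does not carry a single size of step from one core to another, and a small step on one core is no promise of a small step on the next. Nothing measured here explains why the two steps differ.

The cores of compound 1 and compound 3 differ in more than one place, so the compounds shown leave open which of those differences sets the size of the step. Also open, from the compounds shown here alone, is how a smaller amine such as dimethylamino, or a carboxylic acid, would compare with 4-methylpiperazin-1-yl and with hydrogen at this same place on the core of compound 3.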